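This account rests on a few compounds, and the source may have more. Where it says the series, first, only, none or still open, it means among the compounds named here.

Among the measured compounds shown here, compound 1 `CCOc1ccccc1-c1ccc(-c2nc3cnccc3c(N[C@H](CC)C(=O)N(C)C)c2C#N)cc1` is the more lipophilic of the two measured members. In a physicochemical assay for lipophilicity, read by HPLC, at pH 7.5 (a higher number here means a more lipophilic compound, a lower number a more polar compound), compound 1 gives 3.7. The other measured member, compound 2 `CC[C@@H](Nc1c(C#N)c(-c2ccc(-c3cccc(Cl)c3OC)cc2)nc2cnccc12)C(N)=O`, gives in this assay a distribution coefficient of 3.1, a lower number, and the gap between compound 1 and compound 2 lies beyond the usual scatter. For the measured compounds named here, no single-point step between measured compounds is available, so the shared core gives no direct precedent for the change considered here.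

Compound 3 `CCOc1ccccc1-c1ccc(-c2nc3cnccc3c(N[C@H](CC)C(=O)O)c2C#N)cc1`, not yet measured, differs from compound 1 in one place: hydroxy in place of dimethylamino on a carbonyl carbon. For compound 3 the step in this assay is expected to be downward and large, with the estimated step from compound 1 to compound 3 amounting to a number 2.20 log units lower from compound 1 to compound 3 (beyond the scatter). Compound 3 is accordingly estimated at 1.5 in this assay, within a range from 0.7 to 2.3.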

Compound 3, distribution coefficient: 2.1
For compound 3 the middle estimate is 0.60 log units below the measured one; the range from low to high includes it.
By their numbers in this assay, from the lowest: compound 3; then compound 2; then compound 1.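

On the shared core, this position now has its first measured single-place step. In this assay, hydroxy in place of dimethylamino on a carbonyl carbon gives a number 1.60 log units lower from compound 1 to compound 3 (beyond the scatter), so one exchange at this carbonyl carbon, with the saturated chain carbon unchanged, is enough to produce a large change in this read-out. Nothing measured here bears on the origin of this step.

As far as these compounds go, the step rests on a single pair, so how a methylamino or diethylamino group on the same carbonyl carbon would read relative to dimethylamino and hydroxy remains open. Also open, from the compounds shown here alone, is whether the exchange from dimethylcarbamoyl to carboxy gives a step of similar size when other groups are carried elsewhere on the shared core.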